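Swapping a Chloro for a Bromo on the Phenyl Ring

This account rests on a few compounds, and the source may have more. Where it says the series, first, only, none or still open, it means among the compounds named here.

Of the compounds shown here, three sharing one core have been measured in a functional assay on BT-549 cells (Homo sapiens) for inhibition, read by sulforhodamine B assay, with a stated time of 48 h, tested at 10 uM; on this read-out lower numbers stand for less inhibition and higher numbers for more inhibition at the one concentration tested (going by the name of the read-out). Compound 1 `Brc1cn2ccnc2c(-c2ccc3ncn(C4CCCCC4)c3c2)n1` carries a bromo on its core and gives 5.16%. Compound 2 `Fc1ccc(-c2cn3ccnc3c(-c3ccc4ncn(C5CCCCC5)c4c3)n2)cc1` has a 4-fluorophenyl in that position and gives 20.3%. Compound 3 `Clc1ccc(-c2cn3ccnc3c(-c3ccc4ncn(C5CCCCC5)c4c3)n2)cc1` has a 4-chlorophenyl there and gives 23.8%. Of the three, compound 3 has a number that is no lower than any other: the step of a number 3.5 percentage points higher from compound 2 to compound 3 (within the scatter) stays within the usual scatter, while the step of a number 18.6 percentage points higher from compound 1 to compound 3 (beyond the scatter) lies beyond it, as does the step of a number 15.1 percentage points higher from compound 1 to compound 2 (beyond the scatter).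

Compound 4 `Brc1ccc(-c2cn3ccnc3c(-c3ccc4ncn(C5CCCCC5)c4c3)n2)cc1` differs from compound 3 in one place: bromo in place of chloro on an aromatic carbon. Among the compounds with values here, the one measured step that bears on this is the exchange of one halogen for another on the same phenyl ring, from compound 2 to compound 3, which was a number 3.5 percentage points higher from compound 2 to compound 3 (within the scatter) and thus within the scatter. The larger steps from compound 1 arose from adding a whole phenyl ring and do not speak to a change of halogen.

Compound 4 is therefore expected to show a step of about a number 1.2 percentage points higher from compound 3 to compound 4 (within the scatter) in this assay, nothing beyond the scatter. The estimate for compound 4 is 25%, with a likely range from 12% to 38%.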

Compound 4, a percentage reported as inhibition, at one concentration (the size of the read-out at that concentration, not a potency): 35.1%
The estimate for compound 4 lay 10.1 percentage points below the measured number; the range from low to high includes it.
By their numbers in this assay, from the lowest: compound 1; then compounds 2 and 3 (each within the scatter of the next); then compound 4.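

In this assay the choice of halogen on the phenyl ring now makes a visible difference: bromo in place of chloro gives a number 11.3 percentage points higher from compound 3 to compound 4 (beyond the scatter) and bromo in place of fluoro gives a number 14.8 percentage points higher from compound 2 to compound 4 (beyond the scatter) even though fluoro and chloro could not be told apart. The phenyl ring alone therefore does not set the number, since 4-bromophenyl in place of the bromo on the core gives a number 29.9 percentage points higher from compound 1 to compound 4 (beyond the scatter) and what the ring carries at this position also counts. Nothing available explains why bromo stands apart from the other two halogens.

Going by these compounds, it remains open whether a group other than a halogen at this position on the phenyl ring, such as an amine, a methoxy group or a carboxylic acid, would raise or lower the number. It is also unknown whether the gain from chloro to bromo would hold with a change elsewhere on the shared core, or what these single-concentration readings would mean for potency.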